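The source may hold more compounds than are shown below. What is called first, only, known or untested is meant among the compounds shown, and "the series" means these compounds.

Compound 1 `CC(C)c1c(Cc2c(F)cccc2Cl)nc(SCC(=O)c2ccc(F)cc2)[nH]c1=O`: > 56000 nM
Compound 2 `CC(C)c1c(Cc2c(F)cccc2F)nc(SCC(=O)c2ccccc2)[nH]c1=O`: > 60000 nM

In an ADME assay on MT4 cells (Homo sapiens) for cytotoxicity, read by MTT assay (a lower number here means that less compound is tolerated, a higher number that more compound is tolerated), compound 2 gives > 60000 nM, which is a limit and not a number. Compound 1 gives > 56000 nM, which is also a limit. Compound 3 `CC(C)c1c(Cc2c(F)cccc2F)nc(SCC(=O)c2ccc(F)cc2)[nH]c1=O` differs from compound 2 by one change: fluoro in place of hydrogen on an aromatic carbon, with fluoro in place of hydrogen on an aromatic carbon, para to a large group. Compound 1 already carries the 4-fluorophenyl group and still gives > 56000 nM. Among the compounds with values here, no measured step shows this change alone, so none beyond the scatter is expected. The expected step of an at least 1.0-fold lower number from compound 2 to compound 3 (0.01 log units; that floor lies within the scatter) is therefore small. For compound 3 the estimate is 58000 nM, with an expected range from 25000 nM to 70000 nM.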

Compound 3, half-maximal cytotoxic concentration: > 58000 nM
Compound 3 was reported as a limit (the forecaster's own chance of this, stated with the estimate: 80%); the middle value sits exactly at the limit.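

Within the data shown here, compound 1, compound 2 and compound 3 each give only a limit in this assay, so no step between them can be read. The compounds shown leave open whether fluoro in place of hydrogen or of chloro changes the tolerated concentration at all.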